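Swapping the aryl group on the enone chain of compound 2

The source may hold more compounds than are shown below. What is called first, only, known or untested is meant among the compounds shown, and "the series" means these compounds.

Two compounds are known so far. In a functional assay on M14 cells (Homo sapiens) for inhibition (on this read-out lower numbers stand for stronger inhibition of growth and higher numbers for weaker inhibition of growth), compound 1 `COc1cc(/C=C/C(=O)c2cccc(-n3cc(-c4ccc(Cl)cc4)[nH]c3=O)c2)cc(OC)c1OC` gives 4360 nM, and compound 2 `COc1ccc(-c2cn(-c3cccc(C(=O)/C=C/c4ccc(O)c(OC)c4)c3)c(=O)[nH]2)cc1` gives 5140 nM, which is the higher of the two numbers but within the scatter of compound 1. Compound 3 `COc1ccc(-c2cn(-c3cccc(C(=O)/C=C/c4cc(OC)c(OC)c(OC)c4)c3)c(=O)[nH]2)cc1` differs from compound 2 by one change: 3,4,5-trimethoxyphenyl in place of 4-hydroxy-3-methoxyphenyl on a double-bonded chain carbon bound to a double-bonded chain carbon. Compound 1 already carries this trimethoxyphenyl group and gives 4360 nM, so no step beyond the scatter is expected. Compound 3 is therefore expected to reach about 4200 nM in this assay, somewhere between 1600 nM and 11000 nM, a step of a 1.2-fold lower number from compound 2 to compound 3 (0.09 log units; within the scatter).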

Compound 3, concentration for 50% growth inhibition: 1850 nM
The estimate for compound 3 lay 2.3-fold (0.36 log units) above the measured number; measured number inside the range.
By their numbers in this assay, from the lowest: compound 3; then compounds 1 and 2 (each within the scatter of the next).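

In this assay the step from 4-hydroxy-3-methoxyphenyl to 3,4,5-trimethoxyphenyl on the chain is a 2.8-fold lower number from compound 2 to compound 3 (0.44 log units; beyond the scatter) and so the group at this position does affect growth inhibition. With the trimethoxyphenyl group held fixed, methoxy in place of chloro on an aromatic carbon gives a 2.4-fold lower number from compound 1 to compound 3 (0.37 log units; beyond the scatter) and so this second place matters too, which compounds 1 and 2 could not show because they differ in two places. No measurement here explains either step.

Going by these compounds, whether losing the hydroxy or adding methoxy groups drives the first step remains open. So does how this position would respond to an amine or a carboxylic acid on the aromatic ring.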